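Pyrrole replaces pyridinyloxy on a shared quinolone amide core

The source may report more compounds than this note shows. Statements on the series, on what has been measured and on what is new or still open speak of the compounds shown alone.

Compound 2 `COc1cc(OC)c2c(=O)cc(C(=O)Nc3ccc(Oc4ccc([N+](=O)[O-])cc4)cc3)[nH]c2c1` gives 480 nM in a functional assay on SEM cells (Homo sapiens) for antiproliferative activity, with a stated time of 72 h; on this read-out lower numbers stand for an effect already at smaller amounts and higher numbers for an effect only at larger amounts of compound. Compound 3 `COc1cc(OC)c2c(=O)cc(C(=O)Nc3ccc(Oc4cccnc4)cc3)[nH]c2c1` is reported only as a limit, > 32100 nM. Compound 1 `COc1cc(OC)c2c(=O)cc(C(=O)Nc3ccc(C4CCCCC4)cc3)[nH]c2c1` is reported as "not determined" (no result reported) in this assay.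

In this assay compound 3 thus stands at the limit of the method (the limit of > 32100 nM in this assay, at which 1 of the 3 values shown sits), with no single number to its name. Among the measured compounds shown here, the one measured step, an at least 66-fold higher number from compound 2 to compound 3 (1.82 log units; beyond the scatter), was large, and it is the only step that bears on compound 4 `COc1cc(OC)c2c(=O)cc(C(=O)Nc3ccc(-n4cccc4)cc3)[nH]c2c1`. Compound 4 differs from compound 3 by 1H-pyrrol-1-yl in place of (pyridin-3-yl)oxy on an aromatic carbon. Whether the pyrrole brings the number back toward that of compound 2 cannot be read from a single step, so the expectation is broad. Compound 4 is estimated at 4000 nM, between 500 nM and 32100 nM, which is expected to mean an at least 8.0-fold lower number from compound 3 to compound 4 (0.90 log units; beyond the scatter).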

Compound 4, half-maximal effective concentration: > 77000 nM
Compound 4: no number, only a limit (the forecaster's own chance of this, stated with the estimate: 35%); at least 19-fold (1.28 log units) between middle value and limit.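

Placing 1H-pyrrol-1-yl in place of 4-nitrophenoxy gives an at least 160-fold higher number from compound 2 to compound 4 (2.20 log units; beyond the scatter) in this assay. Compound 4 is reported only as a limit, > 77000 nM, and with compound 3 also a limit, the step between those two cannot be read. On this aromatic carbon, para to a large group, a single number comes only with the 4-nitrophenoxy of compound 2, not with (pyridin-3-yl)oxy or 1H-pyrrol-1-yl.

Going by these compounds, what a plain phenoxy or a 4-aminophenoxy would give at this place stays open. Also open, on these data alone, is whether compound 3 and compound 4 differ at all in this assay.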